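A few compounds are considered here, and "the series" means these few. Any claim that something is new, unique, unknown or untested is made for them only; others in the source may bear on it.

Compound 1, `COc1cc(C)ccc1S(=O)(=O)NC1=NCCN1C(=S)SN1CCn2c1nsc2=S`, in a functional assay on KYSE-510 cells (Homo sapiens) for antiproliferative activity, read by crystal violet staining, with a stated time of 96 h (on this read-out higher numbers stand for weaker inhibition of growth and lower numbers for stronger inhibition of growth), gives compound 1 a value of >= 20000 nM, which is a limit of the assay.
Compound 2, `O=S(=O)(NC1=NCCN1C(=S)SN1CCn2c1nsc2=S)c1ccc(C(F)(F)F)cc1`, in this assay gives compound 2 >= 20000 nM, again a limit.
Compound 3, `O=S(=O)(NC1=NCCN1C(=S)SN1CCn2c1nsc2=S)c1ccccc1Cl`, in this assay gives compound 3 >= 20000 nM, also a limit.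

All three measured compounds thus sit at the same limit (the limit of >= 20000 nM in this assay, at which 3 of the 3 values shown sit), and none of them yields a number. Compound 3 therefore stands nowhere that can be ranked: the step that the two limits leave unreadable from compound 1 to compound 3 and the step that the two limits leave unreadable from compound 2 to compound 3 are both unreadable, as is a step that the two limits leave unreadable from compound 1 to compound 2, because each end is a limit.

Compound 4, `O=S(=O)(NC1=NCCN1C(=S)SN1CCn2c1nsc2=S)c1ccc(Cl)c(Cl)c1Cl`, has not yet been measured in this assay. It differs from compound 3 in one place: 2,3,4-trichlorophenyl in place of 2-chlorophenyl on a sulfonyl sulfur. The measured steps that bear on this change are the three exchanges of the aryl group on the sulfonyl sulfur, and every one of them is unreadable, since all three compounds stop at the limit. Three different aryl groups have given no measurable growth inhibition; a fourth aryl group offers no reason to expect a departure from that picture. Compound 4 is therefore expected to show no readable step, a number no higher from compound 3 to compound 4 (the limit leaves the size open), and most likely to return a limit again. The estimate for compound 4 is 20000 nM, within a range from 6000 nM to 40000 nM.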

Compound 4, concentration for 50% growth inhibition: >= 20000 nM
Compound 4: no number, only a limit; the forecaster's own chance of this, stated with the estimate: 75%; the middle value lies on the limit itself.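

In this assay compound 4 gives >= 20000 nM, a limit and not a number. Its steps to compound 1, compound 2 and compound 3 cannot be read, since every end is a limit: the limit of >= 20000 nM in this assay, at which 4 of the 4 values shown sit. The compounds shown leave open whether any aryl group on the sulfonyl sulfur would give a real number in this assay.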